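The source may hold more compounds than are shown below. What is called first, only, known or untested is meant among the compounds shown, and "the series" means these compounds.

In a functional assay on HepG2 cells (Homo sapiens) for antiproliferative activity, read by MTT assay, with a stated time of 48 h (a higher number here means that more compound is needed for the effect, a lower number that less compound is needed), compound 3 (`CC1=NN(C(=O)CCl)C(c2cc(Br)ccc2O)C1`) gives 12300 nM. Compound 1 (`CC1=NN(C(=O)CCl)C(c2cc(Cl)ccc2O)C1`) gives 20300 nM, which lies within the scatter of compound 3. Compound 2 (`CC1=NN(C(=O)C(F)(F)F)C(c2ccccc2O)C1`) gives 4800 nM, a lower number than that of compound 3 and a gap beyond the scatter. Compound 2 differs from compound 3 in more than one place, so it says little about the change considered here.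

Compound 4 (`CC1=NN(C(=O)CCl)C(c2cc(F)ccc2O)C1`) is still unmeasured. It departs from compound 3 in a single place: fluoro in place of bromo on an aromatic carbon. In words, this is fluoro in place of bromo on an aromatic carbon, para to a hydroxy group.

Among the measured compounds shown here, only one measured step touches this place, namely a 1.7-fold lower number from compound 1 to compound 3 (0.22 log units; within the scatter), where bromo replaces chloro. That exchange stayed within the scatter, so a large jump in this assay is not expected from another such exchange. The expected change is a 1.5-fold higher number from compound 3 to compound 4 (0.17 log units; within the scatter), a small rise in the number that would not clearly exceed the scatter.

For compound 4 the estimated value is 18000 nM, with an expected range from 8000 nM to 40000 nM.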

Compound 4, half-maximal effective concentration: 4210 nM
For compound 4 the middle estimate is 4.3-fold (0.63 log units) above the measured one; measured number below the stated range.
By their numbers in this assay, from the lowest: compounds 4 and 2 (each within the scatter of the next); then compounds 3 and 1 (each within the scatter of the next).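

In this assay, exchanging bromo for fluoro at this place, para to a hydroxy group, gives a 2.9-fold lower number from compound 3 to compound 4 (0.47 log units; beyond the scatter), and exchanging chloro for fluoro gives a 4.8-fold lower number from compound 1 to compound 4 (0.68 log units; beyond the scatter). The earlier chloro and bromo pair stayed within the scatter, so only now is it clear that this position responds to the choice of halogen, with fluoro standing apart from the other two. Nothing available here explains why fluoro behaves differently.

The compounds shown leave open whether a methoxy group, a nitrile or a plain hydrogen at this place, on the same chloroacetyl-bearing core, would match the low number of compound 4 or lose it. Compound 2 cannot settle this, as it differs from compound 4 in more than one place.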